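Swapping Chloro for Fluoro on a Halogenated Phenyl Ring

The compounds below may be only part of what the source reports. "The series", "measured", "known", "first", "only" and "open" are said of these compounds alone.

Of the compounds shown here, three built on one shared core have so far been tested in an ADME assay on microsomes from liver (Homo sapiens) for metabolic stability, tested at 2.5 uM; on this read-out higher numbers stand for fast clearance and lower numbers for slow clearance. Compound 1 `O=S(=O)(c1ccc(F)c(Cl)c1)c1cnc2cc(F)ccc2c1-c1ccc(Cl)cc1` gives 0.39 mL/min in this assay. Compound 2 `O=S(=O)(c1ccc(F)cc1)c1cnc2cc(F)ccc2c1-c1cccc(F)c1` gives 0.95 mL/min, and compound 3 `O=S(=O)(c1cc(F)cc(F)c1)c1cnc2c(F)cccc2c1-c1cccc(Cl)c1` gives 0.64 mL/min. Compound 1 carries the lowest of the three numbers. Its gap to compound 3 lies within the usual scatter of repeated measurements, so those two cannot be told apart on this read-out, whereas compound 2 sits beyond the scatter and shows the faster clearance of that pair.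

Compound 4 `O=S(=O)(c1ccc(F)c(F)c1)c1cnc2cc(F)ccc2c1-c1ccc(Cl)cc1` is the next compound due for this assay. It differs from compound 1 in a single place: fluoro in place of chloro on an aromatic carbon. Seen one bond further out, the same difference reads 3-chloro-4-fluorophenyl to 3,4-difluorophenyl.

Among the compounds with values here, no measured pair in this set shows this particular change, so its size cannot be read from the data. The expectation is a small step, a 1.3-fold higher number from compound 1 to compound 4 (0.11 log units; within the scatter), toward a somewhat higher number, most likely staying within the scatter. Compound 4 is therefore estimated to give 0.5 mL/min, with a plausible range from 0.3 mL/min to 0.9 mL/min.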

Compound 4, intrinsic clearance in a liver preparation (reported as CLH), per the amount of preparation that the assay uses: 0.01 mL/min
The estimate for compound 4 lay 50-fold (1.70 log units) above the measured number; measured number outside the range, below it.
By their numbers in this assay, from the lowest: compound 4; then compounds 1, 3 and 2 (each within the scatter of the next, the first and the last beyond it).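

In this assay, exchanging chloro for fluoro on an aromatic carbon, ortho to a fluoro group and meta to a large group, gives a 39-fold lower number from compound 1 to compound 4 (1.59 log units; beyond the scatter), a large step well beyond the scatter. Within the data shown here, this is the first pair in the set that differs in one place only, so it is also the first direct view of what a single change does on this read-out: turning 3-chloro-4-fluorophenyl into 3,4-difluorophenyl, with the rest of the molecule untouched, moves the number sharply toward slow clearance, so this one atom matters far more than a swap between two halogens might suggest. Nothing available here explains why the number falls so far.

On these data alone, what a methyl group, a methoxy group or a nitrile on this same carbon would do remains open, and so does whether fluoro itself matters or only the loss of chloro. Also open, as far as these compounds go, is whether the same exchange gives a step of this size when the other rings carry different halogens, as they do in compound 2 and compound 3.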